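The source may report more compounds than this note shows. Statements on the series, on what has been measured and on what is new or still open speak of the compounds shown alone.

In a functional assay on HCT-116 cells (Homo sapiens) for antiproliferative activity, read by sulforhodamine B assay, with a stated time of 48 h (a higher number here means a weaker inhibitor, a lower number a stronger inhibitor), compound 1 `COc1cc(O)c(C(=O)/C=C/c2ccc(Br)cc2)c(OC)c1` gives 14000 nM and compound 2 `COc1cc(OC)c(C(=O)/C=C/c2ccc(OC)c(OC)c2)c(OCC=C(C)C)c1` gives 5700 nM as the lower of the two numbers, a gap that lies beyond the usual scatter. Compound 3 `COc1ccc(/C=C/C(=O)c2c(OC)cc(OC)cc2OCC=C(C)C)cc1` has not yet been measured. It differs from compound 2 by a single change, hydrogen in place of methoxy on an aromatic carbon, counted as hydrogen in place of methoxy on an aromatic carbon and read one bond further out as 3,4-dimethoxyphenyl to 4-methoxyphenyl. Going by the values given here, no measured pair of compounds shows this change, and the two values at hand differ in more than one place, so the expectation is a cautious one. The expected step is a 1.4-fold higher number from compound 2 to compound 3 (0.15 log units; within the scatter) as a small rise in the number, within the scatter. For compound 3 the estimated value is 8000 nM with 3000 nM to 20000 nM as the expected range.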

Compound 3, half-maximal inhibitory concentration: 7600 nM
Compound 3: the middle estimate sits 1.1-fold (0.02 log units) above what was measured, and the stated range covers the measured number.
By their numbers in this assay, from the lowest: compounds 2, 3 and 1 (each within the scatter of the next, the first and the last beyond it).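

In this assay, going by these compounds alone, compounds 2 and 3 form the first pair that differs in one place, and hydrogen in place of methoxy on an aromatic carbon gives a 1.3-fold higher number from compound 2 to compound 3 (0.12 log units; within the scatter) as the step. On this ring, ortho to a methoxy group, 3,4-dimethoxyphenyl and 4-methoxyphenyl therefore cannot be told apart in this read-out. This methoxy, with its 2 heavy atoms and its hydrogen-bond acceptor, can thus give way to hydrogen without a shift beyond the scatter.

Going by these compounds, whether the same place tolerates a group of another kind, such as an amine or a carboxylic acid, remains open, as does the outcome of replacing the remaining methoxy on that ring with hydrogen. Nothing on hand offers an explanation for this result.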